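Sulfonyl aryl variation on a shared core: inhibition notes

This account rests on a few compounds, and the source may have more. Where it says the series, first, only, none or still open, it means among the compounds named here.

Measured so far:
compound 1, `CC1CCN(c2c(S(=O)(=O)c3ccc(Cl)cc3)cnc3cc(Cl)ccc23)CC1`: 91%
compound 2, `CC1CCN(c2c(S(=O)(=O)c3ccc(Cl)cc3)cnc3cc(F)ccc23)CC1`: 90%
compound 3, `CC1CCN(c2c(S(=O)(=O)c3ccc(F)c(F)c3)cnc3cc(F)ccc23)CC1`: 94%

All three were run in an assay on isolated protein for displacement of a labelled ligand from metabotropic glutamate receptor 5 (Homo sapiens), with a stated time of 60 min, tested at 1 uM; a lower number here means less inhibition, a higher number more inhibition at the concentration tested (going by the name of the read-out). Compound 1 gives 91%, and the other two values sit within the usual scatter of it: the nearest is compound 2, with a number 1 percentage points lower from compound 1 to compound 2 (within the scatter), and the furthest is compound 3, whose 94% differs from compound 1 only within the scatter.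

Compound 4, `Cc1ccc(S(=O)(=O)c2cnc3cc(Cl)ccc3c2N2CCC(C)CC2)cc1C`, is not yet measured. It differs from compound 1 by 3,4-dimethylphenyl in place of 4-chlorophenyl on a sulfonyl sulfur. Going by the values given here, the one measured step at the same place, a number 4 percentage points higher from compound 2 to compound 3 (within the scatter), exchanged one aryl on the sulfonyl sulfur for another and stayed within the scatter. The fluoro-for-chloro exchange on the core, a number 1 percentage points lower from compound 1 to compound 2 (within the scatter), also stayed within the scatter. On that basis no step beyond the scatter is expected from compound 1 to compound 4, and compound 4 is expected to give 89% in this assay, within 76% to 97%. The expected change is a number 2 percentage points lower from compound 1 to compound 4 (within the scatter).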

Compound 4, a percentage reported as inhibition, at one concentration (the size of the read-out at that concentration, not a potency): 86%
Compound 4: middle estimate off by 3 percentage points, on the high side; low and high end bracket the measured number.
By their numbers in this assay, from the lowest: compounds 4, 2, 1 and 3 (each within the scatter of the next).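

With 3,4-dimethylphenyl in place of 4-chlorophenyl on a sulfonyl sulfur, this assay gives a number 5 percentage points lower from compound 1 to compound 4 (within the scatter). The earlier compounds shown here carried only chlorine or fluorine on this aryl ring, whereas compound 4 carries methyl groups and no halogen there, so halogen on this ring is not needed for a reading within the scatter of compound 1. No measurement shown here accounts for this outcome.

As far as these compounds go, whether the sulfonyl sulfur accepts something other than a substituted phenyl, such as a saturated ring, or an aryl ring bearing a carboxylic acid or an amine, remains open. These readings are also taken at one concentration and give no potency, so any differences in potency among compounds 1 to 4 remain unresolved.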